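Shortening an Acetal Side Chain on a Shared Core

A few compounds are considered here, and "the series" means these few. Any claim that something is new, unique, unknown or untested is made for them only; others in the source may bear on it.

Compound 2 `CCOC(Cn1nc(-c2ccc3oc(N)nc3c2)c2c(N)ncnc21)OCC` gives 100 nM in a functional assay on T98 cells (Homo sapiens) for antiproliferative activity, with a stated time of 5 days (a higher number here means that more compound is needed for the effect, a lower number that less compound is needed), and shares with compound 1 the highest of the three numbers recorded. Compound 1 `Nc1nc2cc(-c3nn(C[C@H]4CCCO4)c4ncnc(N)c34)ccc2o1` gives 100 nM, and the step of no change at the digits printed from compound 1 to compound 2 (within the scatter). Compound 3 `Nc1nc2cc(-c3nn(CC4CCCC4)c4ncnc(N)c34)ccc2o1` gives 10 nM, so that the steps of a 10-fold lower number from compound 1 to compound 3 (1.00 log units; beyond the scatter) and a 10-fold lower number from compound 2 to compound 3 (1.00 log units; beyond the scatter). Compound 4 `COC(Cn1nc(-c2ccc3oc(N)nc3c2)c2c(N)ncnc21)OC` differs from compound 2 by dimethoxymethyl in place of diethoxymethyl on a saturated chain carbon bound to an aromatic nitrogen. Among the measured compounds shown here, no measured step shortens diethoxymethyl to dimethoxymethyl; the nearest guide is the step of no change at the digits printed from compound 1 to compound 2 (within the scatter), in which two oxygen-bearing groups at this position gave the same number within the scatter. A step of no change at the digits printed from compound 2 to compound 4 (within the scatter) is therefore expected. Compound 4 is estimated at 100 nM, with a range from 40 nM to 250 nM.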

Compound 4, half-maximal effective concentration: 100 nM
Estimate against measurement, compound 4: no gap at the digits printed, within the range that was stated.
By their numbers in this assay, from the lowest: compound 3; then compounds 1, 2 and 4 (each within the scatter of the next).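

In this assay, shortening diethoxymethyl to dimethoxymethyl leaves the number in place (no change at the digits printed from compound 2 to compound 4 (within the scatter)), so this trimming of the chain makes no visible difference at this position. Dimethoxymethyl also matches oxolan-2-yl (no change at the digits printed from compound 1 to compound 4 (within the scatter)), whereas replacing cyclopentyl with dimethoxymethyl gives a clear shift (a 10-fold higher number from compound 3 to compound 4 (1.00 log units; beyond the scatter)), so all three oxygen-bearing groups stand apart from cyclopentyl in these four compounds. No supporting measurement explains this. Going by these compounds, whether an amine or a carboxylic acid on this saturated chain carbon would track the oxygen-bearing groups or cyclopentyl remains open.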